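Reversing an Aryl Exchange on a Weakly Active Compound

The source may report more compounds than this note shows. Statements on the series, on what has been measured and on what is new or still open speak of the compounds shown alone.

In a functional assay on A549 cells (Homo sapiens) for antiproliferative activity, read by MTT assay, with a stated time of 72 h (on this read-out lower numbers stand for stronger inhibition and higher numbers for weaker inhibition), compound 1 (`CCNC(=O)c1cc(Oc2ccc(NC(=O)c3nn(-c4ccccc4OC(F)(F)F)c(=O)cc3C)cc2)ccn1`) gives 5280 nM and compound 2 (`CCNC(=O)c1cc(Oc2ccc(NC(=O)c3nn(-c4ccc(Br)cc4F)c(=O)cc3C)cc2)ccn1`) gives 34500 nM. Compound 3 (`CCCNC(=O)c1cc(Oc2ccc(NC(=O)c3nn(-c4ccc(Br)cc4F)c(=O)cc3C)cc2F)ccn1`) gives 235000 nM, the highest of the three numbers and so the weakest inhibition among them. Compound 4 (`CCCNC(=O)c1cc(Oc2ccc(NC(=O)c3nn(-c4ccccc4OC(F)(F)F)c(=O)cc3C)cc2F)ccn1`) is not yet measured. It differs from compound 3 in one place, where 2-(trifluoromethoxy)phenyl takes the place of 4-bromo-2-fluorophenyl on an aromatic nitrogen: 2-(trifluoromethoxy)phenyl in place of 4-bromo-2-fluorophenyl on an aromatic nitrogen. Among the compounds with values here, one measured step bears on this change, the same exchange in the opposite direction, and it is modest but beyond the scatter: a 6.5-fold higher number from compound 1 to compound 2 (0.82 log units; beyond the scatter). That single pair has a different background from compound 3, so its transfer is uncertain. A step of similar size is nevertheless expected in this assay, towards a lower number and stronger inhibition. The expected change is a 6.5-fold lower number from compound 3 to compound 4 (0.81 log units; beyond the scatter). The estimate for compound 4 is 36000 nM, with an expected range of 10000 nM to 125000 nM.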

Compound 4, half-maximal inhibitory concentration: 4220 nM
For compound 4 the middle estimate is 8.5-fold (0.93 log units) above the measured one; measured number below the stated range.
By their numbers in this assay, from the lowest: compounds 4 and 1 (each within the scatter of the next); then compound 2; then compound 3.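

On the core of compound 3, the exchange at this position has a far larger effect than the earlier pair showed: in this assay, 2-(trifluoromethoxy)phenyl in place of 4-bromo-2-fluorophenyl on the aromatic nitrogen gives a 56-fold lower number from compound 3 to compound 4 (1.75 log units; beyond the scatter). The direction is the same on both cores, with 2-(trifluoromethoxy)phenyl going with the lower number each time, but the size of the step does not carry over from one core to the other: the same change on two cores in this assay, a 6.5-fold higher number (0.82 log units; beyond the scatter) from compound 1 to compound 2 and a 56-fold higher number (1.75 log units; beyond the scatter) from compound 4 to compound 3, 8.5-fold (0.93 log units) apart, beyond the scatter of two such steps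

The compounds shown leave open whether the propyl or ethyl chain on the amide or the added fluorine on the shared core sets the size of this exchange. They also leave open how the position would respond to an unsubstituted phenyl or a cyclohexyl group, and how the exchange would behave with a butyl chain on the amide.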